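Swapping the Aryl Group on a Weak Inhibitor

The source may report more compounds than this note shows. Statements on the series, on what has been measured and on what is new or still open speak of the compounds shown alone.

Three compounds have been measured in a functional assay on HL-60 cells (Homo sapiens) for inhibition, read by MTT assay, with a stated time of 48 h, tested at 10 uM; on this read-out higher numbers stand for more inhibition of growth at the one concentration tested and lower numbers for less inhibition of growth:

compound 1 `Cc1cc(=O)c2c(O)c(CN3CCC(N4CCCCC4)CC3)c(O)c([C@H]3CCN(C)C[C@H]3O)c2o1` gives 34%
compound 2 `Cc1cc(=O)c2c(O)c(CN3CCC(Cc4ccccc4)CC3)c(O)c([C@H]3CCN(C)C[C@H]3O)c2o1` gives 28%
compound 3 `Cc1oc2c([C@H]3CCN(C)C[C@H]3O)c(O)cc(O)c2c(=O)c1C(O)c1ccc(Cl)cc1` gives 2%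

Compound 3 stands lowest of the three. Its nearest neighbour is compound 2, whose number is higher by a margin beyond the scatter, and compound 1 lies further still above it. Compound 4 `CCOc1ccc(Br)c(C(O)c2c(C)oc3c([C@H]4CCN(C)C[C@H]4O)c(O)cc(O)c3c2=O)c1` differs from compound 3 in one place: 2-bromo-5-ethoxyphenyl in place of 4-chlorophenyl on a saturated chain carbon bound to an aromatic carbon and an oxygen on a saturated carbon.

Within the data shown here, the only measured step, a number 6 percentage points lower from compound 1 to compound 2 (within the scatter), alters a different part of the shared core and does not touch the group that changes here, so no measured step bears on this change. With no guide to either direction, the step of a number 3 percentage points higher from compound 3 to compound 4 (within the scatter) is expected to stay within the scatter. Compound 4 is therefore estimated at 5%, with a range from -5% to 20%.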

Compound 4, percent growth inhibition at one concentration: 2%
Estimate against measurement, compound 4: 3 percentage points above, within the range that was stated.
By their numbers in this assay, from the lowest: compounds 3 and 4 (each within the scatter of the next); then compounds 2 and 1 (each within the scatter of the next).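

In this assay, among these compounds, putting 2-bromo-5-ethoxyphenyl in place of 4-chlorophenyl on the saturated chain carbon gives no change at the digits printed from compound 3 to compound 4 (within the scatter) as the first reading at this position. Here, then, adding a bromine and an ethoxy group while moving from the chlorine leaves the growth-inhibition number unmoved. No evidence available bears on this result.

Going by these compounds, whether an amine or a carboxylic acid on this aromatic ring would shift the number remains open. So does the effect of replacing the ring with a longer saturated chain.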